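A few compounds are considered here, and "the series" means these few. Any claim that something is new, unique, unknown or untested is made for them only; others in the source may bear on it.

- Compound 1 `CCN(CC)CC(=O)Nc1ccc(Nc2cc(Cl)nc(-c3ccc(OC)cc3)n2)cc1`: 15000 nM
- Compound 2 `CCN(CC)CC(=O)Nc1ccc(Nc2nc(-c3ccc(OC)cc3)nc(Cl)c2-c2ccccc2)cc1`: > 40000 nM
- Compound 3 `COc1ccc(-c2nc(Cl)c(-c3ccccc3)c(Nc3ccc(NC(=O)CN4CCCC4)cc3)n2)cc1`: > 40000 nM

Among the compounds with values here, in a functional assay on HUVEC cells (Homo sapiens) for antiproliferative activity, read by MTT assay, with a stated time of 48 h (a lower number here means a stronger inhibitor, a higher number a weaker inhibitor), compound 1 gives 15000 nM, the only exact number so far, and there is nothing exact to rank it against. Compound 2 reads > 40000 nM, which is a limit of the assay and not a number. Compound 3 reads > 40000 nM, which is likewise a limit.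

Compound 4 `COc1ccc(-c2nc(Cl)cc(Nc3ccc(NC(=O)CN(C)C)cc3)n2)cc1` has not yet been measured. It keeps the core of compound 1 and makes one change, dimethylamino in place of diethylamino on a saturated chain carbon bound to a carbonyl carbon.

Two measured steps offer some guidance. The closer one also replaces diethylamino at this place, with pyrrolidin-1-yl, but it gives no size: a step that the two limits leave unreadable from compound 2 to compound 3. The other is clearly readable, an at least 2.6-fold higher number from compound 1 to compound 2 (0.42 log units; beyond the scatter), but it is a different change, phenyl in place of hydrogen on an aromatic carbon, so it says little here.

With no measured size for a change of this kind, no shift beyond the usual scatter is expected in this assay. The expected step is a 1.1-fold higher number from compound 1 to compound 4 (0.03 log units; within the scatter). For compound 4 the estimated value is 16000 nM, with an expected range from 7000 nM to 35000 nM.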

Compound 4, half-maximal inhibitory concentration: > 40000 nM
Compound 4: no number, only a limit; the forecaster's own chance of this, stated with the estimate: 10%; at least 2.5-fold (0.39 log units) between middle value and limit.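

In this assay, the amine on the saturated chain carbon bound to a carbonyl carbon now has a readable effect, which the earlier pair with the same kind of change could not provide, as the steps between limits cannot be read. Putting dimethylamino in place of diethylamino gives an at least 2.6-fold higher number from compound 1 to compound 4 (0.42 log units; beyond the scatter), so this small change on the core of compound 1 moves the result towards weaker inhibition, beyond the usual scatter, and the position is not indifferent to the amine it carries. Only the minimum size of this step is known, as compound 4 has a limit and not a number, and the assay cannot show how much weaker it is: the limit of > 40000 nM in this assay, at which 3 of the 4 values shown sit.

The compounds shown leave open whether an amine larger than diethylamino, such as piperidin-1-yl or morpholin-4-yl, would bring a lower number than compound 1 at this place. They also leave open how pyrrolidin-1-yl would read on the core of compound 1 without the added phenyl, and what a longer chain carrying the diethylamino group would do.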